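The compounds below may be only part of what the source reports. "The series", "measured", "known", "first", "only" and "open" are said of these compounds alone.

Among the compounds with values here, compound 1 `CC(C)N(C)c1nc(Cc2c(F)cccc2F)cc(=O)[nH]1` gives 85000 nM in an ADME assay on MT4 cells (Homo sapiens) for cytotoxicity, read by MTT assay, with a stated time of 4 days (a higher number here means that more compound is tolerated, a lower number that less compound is tolerated), and is the only compound with a plain number here. Compound 2 `O=c1cc(Cc2c(F)cccc2F)nc(N2CCCCCC2)[nH]1` gives > 78000 nM in this assay, which is a limit of the assay and not a number. The step that the limit leaves unreadable from compound 1 to compound 2 is therefore of unreadable size; the limit of > 78000 nM in this assay, at which 1 of the 2 values shown sits, is all that is known of it. Compound 3 `O=c1cc(Cc2c(F)cccc2F)nc(-n2cccc2)[nH]1` differs from compound 1 by 1H-pyrrol-1-yl in place of isopropyl(methyl)amino on an aromatic carbon. With no readable step in the series, a change within the scatter is expected for compound 3, namely a 1.1-fold lower number from compound 1 to compound 3 (0.03 log units; within the scatter). Compound 3 is thus estimated at 80000 nM in this assay, between 30000 nM and 200000 nM.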

Compound 3, half-maximal cytotoxic concentration: > 87000 nM
Compound 3 gave a limit, no number; the forecaster's own chance of this, stated with the estimate: 40%; middle value at least 1.0-fold (0.03 log units) from the limit.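

Compound 3 gives > 87000 nM in this assay, which is a limit of the assay and not a number. The step is an at least 1.0-fold higher number from compound 1 to compound 3 (0.01 log units; that floor lies within the scatter), so an aromatic 1H-pyrrol-1-yl on this carbon, between two ring nitrogen atoms, brings no readable fall from the open-chain isopropyl(methyl)amino. The steps that touch compound 2 cannot be read. From the compounds shown here alone, how far the tolerated concentration of compound 3 extends remains open. Going by these compounds, whether a carboxylic acid or a primary amine on this carbon would give a readable step also remains open.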